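Terminal aryl fluorination on the acylhydrazone arm

This account rests on a few compounds, and the source may have more. Where it says the series, first, only, none or still open, it means among the compounds named here.

Compound 1 `Brc1cccc(CSc2nnc(-c3ccncc3)n2-c2ccccc2)c1` gives 8170 nM in a functional assay on HCT-116 cells (Homo sapiens) for inhibition, read by MTT assay, with a stated time of 48 h (a lower number here means a stronger inhibitor, a higher number a weaker inhibitor), and compound 2 `c1ccc(CSc2nnc(-c3ccncc3)n2-c2ccccc2)cc1` gives 16900 nM. Going by the values given here, the one single-point step in the set, a 2.1-fold higher number from compound 1 to compound 2 (0.32 log units; beyond the scatter), is bromo to hydrogen on the benzyl ring. Compound 3 `O=C(CSc1nnc(-c2ccncc2)n1-c1ccccc1)N/N=C/c1ccccc1`, carrying the acylhydrazone arm in place of the benzyl thioether, gives 14700 nM; that places it second highest of the three numbers, within the scatter of compound 2 and also within the scatter of compound 1.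

Compound 4 `O=C(CSc1nnc(-c2ccncc2)n1-c1ccccc1)N/N=C/c1ccc(F)cc1` differs from compound 3 by fluoro in place of hydrogen on an aromatic carbon. No measured step mirrors this exactly; the bromo-to-hydrogen step on the other series, a 2.1-fold higher number from compound 1 to compound 2 (0.32 log units; beyond the scatter), is the only halogen change shown and was modest in size, so a halogen entering is taken here as the reverse direction at a smaller scale. The expected step is therefore a 1.3-fold lower number from compound 3 to compound 4 (0.13 log units; within the scatter), not beyond the scatter. Compound 4 is estimated at 11000 nM, with a range of 4500 nM to 28000 nM.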

Compound 4, half-maximal inhibitory concentration: 7040 nM
Compound 4: the middle estimate sits 1.6-fold (0.19 log units) above what was measured; the range from low to high includes it.
By their numbers in this assay, from the lowest: compounds 4, 1, 3 and 2 (each within the scatter of the next, the first and the last beyond it).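

On the acylhydrazone arm, the change from phenyl to 4-fluorophenyl gives a step in this assay that lies beyond the scatter (a 2.1-fold lower number from compound 3 to compound 4 (0.32 log units; beyond the scatter)), so the terminal ring of this arm responds to a single fluoro on an aromatic carbon, which compound 3 alone could not show. Together with the bromo-to-hydrogen step on the benzyl series (a 2.1-fold higher number from compound 1 to compound 2 (0.32 log units; beyond the scatter)), this makes two pairs in which the halogen-bearing partner has the lower number, and no pair shown goes against it, though the halogen, the arm and the ring differ between them. No measurement shown bears on the reason for this step.

As far as these compounds go, it remains open whether chloro, bromo, methoxy or an amine at the same place would move the number in the same direction. Also open, from the compounds shown here alone, is whether fluoro on another carbon of this ring, or on the benzyl ring of the thioether series, would give a step of similar size.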